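A Second Benzoyl on the Amide-Type Nitrogen

The source may report more compounds than this note shows. Statements on the series, on what has been measured and on what is new or still open speak of the compounds shown alone.

The shared core appears in compound 1 `COc1cccc(NN=C2C(Cl)=C(Cl)C(Cl)=C2Cl)c1`, compound 2 `O=C(NN=C1C(Cl)=C(Cl)C(Cl)=C1Cl)c1ccccc1` and compound 3 `CC(=O)NN=C1C(Cl)=C(Cl)C(Cl)=C1Cl`. In a functional assay on MM1.S cells (Homo sapiens) for cytotoxicity, read by MTT assay, with a stated time of 48 h (a higher number here means a weaker inhibitor, a lower number a stronger inhibitor), compound 1 gives > 3000 nM, which is the limit of > 3000 nM in this assay, at which 1 of the 3 values shown sits, and not a number. In this assay compound 2 gives 800 nM, the only number shown among the three. For compound 3 the result in this assay is "not determined" (no result reported). Compound 4 `O=C(c1ccccc1)N(N=C1C(Cl)=C(Cl)C(Cl)=C1Cl)C(=O)c1ccccc1` is not yet measured; it differs from compound 2 by benzoyl in place of hydrogen on an amide-type nitrogen, so a benzoyl enters where a hydrogen leaves. For the measured compounds named here, no step between measured compounds is available to size this change. Compound 4 is expected to give 1500 nM, within 500 nM to 4000 nM. The expected step of a 1.9-fold higher number from compound 2 to compound 4 (0.27 log units; within the scatter) lies near the scatter, leaning toward weaker inhibition.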

Compound 4, half-maximal inhibitory concentration: 2000 nM
Compound 4: the middle estimate sits 1.3-fold (0.12 log units) below what was measured; measured number inside the range.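

For the compounds shown here, putting a benzoyl in place of the hydrogen on the amide-type nitrogen gives the first sized change at this position: in this assay there is a 2.5-fold higher number from compound 2 to compound 4 (0.40 log units; beyond the scatter). The loss is modest, and compound 4 still gives a number, 2000 nM, not a limit. Nothing among the data shown accounts for this step. On these data alone, what a methyl or a longer chain in place of that hydrogen would do remains open, as does the effect of a carboxylic acid on the benzoyl.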